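The source may report more compounds than this note shows. Statements on the series, on what has been measured and on what is new or still open speak of the compounds shown alone.

Working notes on the series. The shared core, carrying a phenyl on one ring and a substituted aryl on another, is held constant throughout; the chain and its terminal group vary. Compound 1 `COc1cccc(-c2nn(-c3ccccc3)cc2-c2ccnc(NCCNC(=O)Nc3cccc(C(F)(F)F)c3)c2)c1` gives in a functional assay on SNB-75 cells (Homo sapiens) for cytotoxicity (a higher number here means that more compound is tolerated, a lower number that less compound is tolerated), a value of 100000 nM. Compound 2 `COc1cccc(-c2nn(-c3ccccc3)cc2-c2ccnc(NCCCNC(=O)Nc3ccc(Cl)c(Cl)c3)c2)c1` gives in this assay a value of 100000 nM. Compound 3 `O=C(NCCCNc1cc(-c2cn(-c3ccccc3)nc2-c2cccc(O)c2)ccn1)c1ccccc1`, with a benzamide at the end of the chain, gives in this assay a value of 100000 nM. On these numbers compound 3 stands level with compound 1 and compound 2 at the digits shown; none of the three is separated from the others beyond the scatter, so no order among them can be read.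

Compound 4 `O=C(NCCCNc1cc(-c2cn(-c3ccccc3)nc2-c2cccc(O)c2)ccn1)c1ccc(F)cc1` differs from compound 3 by one change: fluoro in place of hydrogen on an aromatic carbon. Going by the values given here, no pair of measured compounds shows this kind of step, so nothing in the data speaks for a shift in either direction. The step from compound 3 to compound 4 in this assay is expected to be no change at the digits printed from compound 3 to compound 4 (within the scatter), nothing beyond the scatter. Compound 4 is therefore estimated at 100000 nM in this assay, with a range from 50000 nM to 200000 nM.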

Compound 4, concentration lethal to 50% of the cells: 74000 nM
For compound 4 the middle estimate is 1.4-fold (0.13 log units) above the measured one; the measured number falls inside the stated range.
By their numbers in this assay, from the lowest: compounds 4, 1, 2 and 3 (each within the scatter of the next).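

Going by these compounds alone, this is the first step that changes one place only: going from phenyl to 4-fluorophenyl at the end of the chain gives a 1.4-fold lower number from compound 3 to compound 4 (0.13 log units; within the scatter) in this assay. At this position on the benzamide ring, then, fluoro in place of hydrogen does not separate the two compounds, and no order between them can be read. Nothing at hand bears on the reason for this result.

On these data alone, whether a bromo, a methoxy or an amine on this same aromatic carbon would give a step beyond the scatter remains open. So does the outcome of a longer chain, or of a carboxylic acid in place of the terminal benzamide, with the shared core held constant.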